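Swapping a saturated ring for an aromatic one

A few compounds are considered here, and "the series" means these few. Any claim that something is new, unique, unknown or untested is made for them only; others in the source may bear on it.

Among the measured compounds shown here, in an assay on CHO cells for antagonist activity at transient receptor potential cation channel subfamily V member 1 (Homo sapiens), read by FLIPR (on this read-out higher numbers stand for weaker inhibition and lower numbers for stronger inhibition), compound 1 `CCC(C(=O)NCc1ccc(C(F)(F)F)nc1N1CCC(C)CC1)c1ccc(NS(C)(=O)=O)c(F)c1` gives 1.6 nM and compound 2 `CC1CCN(c2nc(C(F)(F)F)ccc2CNC(=O)C(c2ccc(NS(C)(=O)=O)c(F)c2)C2CCCCC2)CC1` gives 31.1 nM, so compound 2 holds the higher of the two numbers, the weaker result, and the single step recorded, a 19-fold higher number from compound 1 to compound 2 (1.29 log units; beyond the scatter), is the only guide available. Compound 3 `CC1CCN(c2nc(C(F)(F)F)ccc2CNC(=O)C(c2ccc(F)cc2)c2ccc(NS(C)(=O)=O)c(F)c2)CC1` is the next change at the same place: 4-fluorophenyl in place of cyclohexyl on a saturated chain carbon bound to an aromatic carbon and a carbonyl carbon. For the measured compounds named here, no measured step matches this exchange; the one recorded step shows that enlarging the group on this saturated chain carbon from ethyl to cyclohexyl raised the number a great deal, but the entering 4-fluorophenyl is about the same size as the leaving cyclohexyl, so that step cannot be carried over directly. The estimate for compound 3 in this assay is therefore a step of a 2.6-fold lower number from compound 2 to compound 3 (0.41 log units; beyond the scatter), towards a somewhat lower number with wide uncertainty. Compound 3 is expected to give 12 nM, within a range from 2 nM to 70 nM.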

Compound 3, inhibition constant: 3.4 nM
Beside the measured number, compound 3's estimate is 3.5-fold (0.55 log units) above it, within the range that was stated.
By their numbers in this assay, from the lowest: compound 1; then compound 3; then compound 2.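

In this assay, the saturated chain carbon bound to an aromatic carbon and a carbonyl carbon turns out to respond to more than the count of atoms in its group: 4-fluorophenyl, with 7 heavy atoms, in place of cyclohexyl, with 6, gives a 9.1-fold lower number from compound 2 to compound 3 (0.96 log units; beyond the scatter). Most of the loss seen with cyclohexyl is thus recovered, yet the small ethyl group still keeps a narrow lead, as 4-fluorophenyl in place of ethyl gives a 2.1-fold higher number from compound 1 to compound 3 (0.33 log units; beyond the scatter). Nothing at hand explains why the aromatic ring gives a lower number than the saturated one.

The compounds shown leave open whether the aromatic ring itself or its fluorine accounts for this result, a question that plain phenyl would address. From the compounds shown here alone, how an isopropyl group or a pyridyl ring would fare at this carbon also remains open.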